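Shifting the methyl on the benzyl thioether of compound 2

The source may report more compounds than this note shows. Statements on the series, on what has been measured and on what is new or still open speak of the compounds shown alone.

Compound 2 `Cc1ccccc1CSc1n[nH]c(-n2[se]c3ccccc3c2=O)n1` is the second highest of the three numbers in an ADME assay on L929 cells (Mus musculus) for antiproliferative activity, read by CCK-8 assay, with a stated time of 48 h (on this read-out higher numbers stand for weaker inhibition and lower numbers for stronger inhibition), where compound 2 gives 15600 nM. For the measured compounds named here, compound 1 `CC(C)CSc1n[nH]c(-n2[se]c3ccccc3c2=O)n1` gives 33400 nM, and the step of a 2.1-fold lower number from compound 1 to compound 2 (0.33 log units; beyond the scatter) is the one measured change here. Compound 3 `O=c1c2ccccc2[se]n1-c1nc(SCc2ccc([N+](=O)[O-])cc2)n[nH]1` gives 7430 nM, a lower number than compound 2. Compound 4 `Cc1cccc(CSc2n[nH]c(-n3[se]c4ccccc4c3=O)n2)c1` differs from compound 2 only by 3-methylphenyl in place of 2-methylphenyl on a saturated chain carbon bound to a sulfur. Going by the values given here, no measured step moves the methyl around the ring, so the one measured step gives no direction for this change, and no step beyond the scatter is expected in this assay. Compound 4 is therefore estimated at 15000 nM, within 7000 nM to 33000 nM, the expected step being a 1.0-fold lower number from compound 2 to compound 4 (0.02 log units; within the scatter).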

Compound 4, half-maximal inhibitory concentration: > 50000 nM
Compound 4 ended at the assay's limit; the forecaster's own chance of this, stated with the estimate: 5%; at least 3.3-fold (0.52 log units) between middle value and limit.
By their numbers in this assay, from the lowest: compound 3; then compound 2; then compound 1. At a limit, above all of these: compound 4.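

In this assay, for the compounds shown here, the place of the methyl on the benzyl group matters, which no earlier compound could show: the change from 2-methylbenzyl to 3-methylbenzyl gives an at least 3.2-fold higher number from compound 2 to compound 4 (0.50 log units; beyond the scatter). The entry for compound 4 is a limit of the assay, not a number: the limit of > 50000 nM in this assay, at which 1 of the 4 values shown sits. Against the isopropyl group, 3-methylphenyl gives an at least 1.4-fold higher number from compound 1 to compound 4 (0.17 log units; that floor lies within the scatter), so this floor does not separate the two beyond the scatter. From the compounds shown here alone, it remains open whether a chlorine or a methoxy group in place of that methyl on 3-methylphenyl would also raise the number, and how a plain unsubstituted benzyl group would stand.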